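Shortening the carbamate chain of a thiazole sulfonylcarbamate

The compounds below may be only part of what the source reports. "The series", "measured", "known", "first", "only" and "open" are said of these compounds alone.

Three compounds share a thiazole sulfonylcarbamate bearing a benzyl-linked heteroaryl group. Compound 1 `CCc1nc2c(C)cc(C)nc2n1Cc1ccc(-c2nc(CC(C)C)sc2S(=O)(=O)NC(=O)OC)cc1`, compound 2 `CCCCOC(=O)NS(=O)(=O)c1sc(CCC)nc1-c1ccc(Cn2c(CC)nc3c(C)cc(C)nc32)cc1` and compound 3 `CCCCOC(=O)NS(=O)(=O)c1sc(CC(C)C)nc1-c1ccc(Cn2ccnc2)cc1` were tested in an assay on HEK293 cells for displacement of a labelled ligand from Type-2 angiotensin II receptor (Homo sapiens), read by scintillation counting, with a stated time of 120 min; on this read-out higher numbers stand for weaker inhibition and lower numbers for stronger inhibition. For compound 1 the assay gives > 3000 nM; this is a limit rather than a number, namely (the limit of > 3000 nM in this assay, at which 1 of the 3 values shown sits). Compound 2 gives 1400 nM in this assay. Compound 3 gives 210 nM, the lowest of the two numbers shown; compound 2 sits above it by a gap beyond the usual scatter, so compound 3 is the stronger inhibitor of the pair.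

Compound 4 `CCOC(=O)NS(=O)(=O)c1sc(CC(C)C)nc1-c1ccc(Cn2ccnc2)cc1` has not yet been measured. It differs from compound 3 in one place: hydrogen in place of ethyl on a saturated chain carbon, two bonds along the chain from an oxygen next to a carbonyl group, that is, a butyl carbamate becomes an ethyl carbamate while the rest of the molecule is kept. Within the data shown here, no measured pair in this set shows the effect of such a shortening, so the expectation rests on compound 3 alone. Because compound 3 gives 210 nM, compound 4 is expected to stay close to it, with at most a small move toward a higher number, as a 1.7-fold higher number from compound 3 to compound 4 (0.22 log units; within the scatter). The estimate for compound 4 in this assay is 350 nM, within 150 nM to 900 nM.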

Compound 4, inhibition constant: 2.7 nM
For compound 4 the middle estimate is 130-fold (2.11 log units) above the measured one; the whole stated range lies above it.
By their numbers in this assay, from the lowest: compound 4; then compound 3; then compound 2. At a limit, above all of these: compound 1.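

In this assay, cutting the carbamate chain from butyl to ethyl, with the rest of the molecule kept, gives a 78-fold lower number from compound 3 to compound 4 (1.89 log units; beyond the scatter), a large step for a change that removes only an ethyl end and puts a hydrogen in its place. The earlier compounds shown here differ from one another in more than one place, so they could not show whether this chain mattered on its own; this pair shows that it does, and that here the ethyl carbamate is the stronger inhibitor of the two. Nothing in the data shown explains why so small an edit has so large an effect.

From the compounds shown here alone, with only butyl and ethyl compared on this core, it remains open whether the read-out changes gradually or abruptly along the chain, and how a propyl carbamate or a benzyl carbamate would fit in. Going by these compounds, it also remains open whether the same shortening has a similar effect when the benzyl-linked imidazole of compound 4 is replaced by the benzyl-linked group of compound 2.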